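Swapping a triple-bonded chain for a saturated one

The source may report more compounds than this note shows. Statements on the series, on what has been measured and on what is new or still open speak of the compounds shown alone.

Compound 1 `C#C[C@@]1(O)[C@@H](CO)O[C@@H](n2cc(Cl)c3c(N)ncnc32)[C@@H]1O` is the stronger of the two measured nucleosides in a functional assay on L1210 cells (Mus musculus) for antiproliferative activity, read by cell counting, with a stated time of 48 h (on this read-out higher numbers stand for weaker inhibition and lower numbers for stronger inhibition), where compound 1 gives 14 nM; compound 2 `C#C[C@@]1(O)[C@@H](CO)O[C@@H](n2cc(C(F)(F)F)c3c(N)ncnc32)[C@@H]1O` gives 110 nM in this assay, a change of a 7.9-fold higher number from compound 1 to compound 2 (0.90 log units; beyond the scatter). Compound 3 `CC[C@@]1(O)[C@@H](CO)O[C@@H](n2cc(Cl)c3c(N)ncnc32)[C@@H]1O` differs from compound 1 by ethyl in place of ethynyl on a saturated ring carbon. Going by the values given here, that measured step altered a different part of the shared core, so no measured step bears directly on this change. Compound 3 is therefore expected to show a step of a 36-fold higher number from compound 1 to compound 3 (1.55 log units; beyond the scatter) in this assay, toward weaker inhibition. The estimate for compound 3 is 500 nM, within 50 nM to 5000 nM.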

Compound 3, half-maximal inhibitory concentration: 1200 nM
Compound 3: the middle estimate sits 2.4-fold (0.38 log units) below what was measured, within the range that was stated.
By their numbers in this assay, from the lowest: compound 1; then compound 2; then compound 3.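

On this saturated ring carbon, ethyl in place of ethynyl gives an 86-fold higher number from compound 1 to compound 3 (1.93 log units; beyond the scatter) in this assay, so this position is sensitive to the change, not only the aromatic carbon varied earlier. Both groups have 2 heavy atoms, and the visible loss is the triple bond outside aromatic rings. No measurement here explains the loss. Still open, on these data alone, is how a vinyl group, with its double bond, or a nitrile would fare at this ring carbon. Also open, as far as these compounds go, is whether the step would be similar with trifluoromethyl in place of chloro.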